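The compounds below may be only part of what the source reports. "The series", "measured", "known", "first", "only" and "open" are said of these compounds alone.

Compound 1 `C=CC(=O)Nc1cc(Nc2ncc3ncn(-c4ccc(CC)cc4)c3n2)c(OC)cc1N(C)CCN(C)C` sits as the second highest of the three numbers measured in an ADME assay on HT-29 cells (Homo sapiens) for cytotoxicity, read by MTT assay, with a stated time of 72 h (on this read-out higher numbers stand for weaker inhibition and lower numbers for stronger inhibition), where compound 1 gives 8180 nM. Its nearest neighbour is compound 3 `C=CC(=O)Nc1cc(Nc2ncc3ncn(-c4ccccc4F)c3n2)c(OC)cc1N(C)CCN(C)C`, which in this assay gives 9750 nM, a gap that stays within the scatter as shown by a 1.2-fold higher number from compound 1 to compound 3 (0.08 log units; within the scatter). Further away lies compound 2 `C=CC(=O)Nc1cc(Nc2ncc3ncn(-c4ccc(Br)cc4)c3n2)c(OC)cc1N(C)CCN(C)C`, which in this assay gives 1460 nM. The move to compound 4 `C=CC(=O)Nc1cc(Nc2ncc3ncn(-c4ccc(F)c(Br)c4)c3n2)c(OC)cc1N(C)CCN(C)C` is 3-bromo-4-fluorophenyl in place of 4-ethylphenyl on an aromatic nitrogen. For the measured compounds named here, two measured steps bear on it. The bromo in place of ethyl on an aromatic carbon gave a 5.6-fold lower number from compound 1 to compound 2 (0.75 log units; beyond the scatter), a modest step beyond the scatter, and the reverse direction showed up again as a 6.7-fold higher number from compound 2 to compound 3 (0.82 log units; beyond the scatter) when the bromo was lost. Since compound 4 keeps a bromo on the ring that enters, the number in this assay is expected to fall by about a 4.5-fold lower number from compound 1 to compound 4 (0.66 log units; beyond the scatter), landing near compound 2. Compound 4 is therefore estimated at 1800 nM, within a range from 600 nM to 5500 nM.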

Compound 4, half-maximal inhibitory concentration: 3640 nM
Beside the measured number, compound 4's estimate is 2.0-fold (0.31 log units) below it, and the stated range covers the measured number.
By their numbers in this assay, from the lowest: compound 2; then compound 4; then compounds 1 and 3 (each within the scatter of the next).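

In this assay the 3-bromo-4-fluorophenyl group on the aromatic nitrogen sets compound 4 apart from all three earlier compounds, with a 2.2-fold lower number from compound 1 to compound 4 (0.35 log units; beyond the scatter) and a 2.7-fold lower number from compound 3 to compound 4 (0.43 log units; beyond the scatter) but also a 2.5-fold higher number from compound 2 to compound 4 (0.40 log units; beyond the scatter) in the opposite direction. A bromo-bearing ring thus again goes with a lower number than the 4-ethylphenyl and 2-fluorophenyl rings, yet 3-bromo-4-fluorophenyl keeps only part of the drop seen with 4-bromophenyl, so the presence of a bromo does not alone set the number. Nothing available here explains that gap.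

The compounds shown do not separate the part played by the added fluoro from that of the bromo's place on the ring. Going by these compounds, it also stays open whether a ring carrying an amine, a carboxylic acid or a longer chain would fall in the same order.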